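Aryl variation on the shared core: outlook for compound 4

The compounds below may be only part of what the source reports. "The series", "measured", "known", "first", "only" and "open" are said of these compounds alone.

Measured compounds:
- In a functional assay on trachea (Cavia porcellus) (on this read-out lower numbers stand for stronger inhibition and higher numbers for weaker inhibition), compound 1 `CCN1CC[C@@]2(OC)OC(N)=C(C#N)[C@@H](c3ccccc3)[C@@H]2C1` gives 23400 nM
- In this assay compound 2 `CCN1CC[C@@]2(OC)OC(N)=C(C#N)[C@@H](c3ccc(Br)cc3)[C@@H]2C1` gives 13200 nM
- In this assay compound 3 `CCN1CC[C@@]2(OC)OC(N)=C(C#N)[C@@H](c3ccc(Cl)cc3Cl)[C@@H]2C1` gives 27100 nM

Going by the values given here, compound 3 has the highest number of the three, though its gap to compound 1 is within the scatter, and only the step from compound 2 is beyond it: a 2.1-fold higher number from compound 2 to compound 3 (0.31 log units; beyond the scatter). The step from the unsubstituted parent reads a 1.2-fold higher number from compound 1 to compound 3 (0.06 log units; within the scatter).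

Compound 4 `CCN1CC[C@@]2(OC)OC(N)=C(C#N)[C@@H](c3ccc(OC)cc3)[C@@H]2C1` carries the change (4-methoxyphenyl in place of 2,4-dichlorophenyl on a saturated ring carbon). Among the compounds with values here, two measured steps bear on it. The 4-bromophenyl analogue shows what a single group at that aryl position does: a 1.8-fold lower number from compound 1 to compound 2 (0.25 log units; within the scatter). The 2,4-dichlorophenyl analogue, read against the same compound, shows a 2.1-fold higher number from compound 2 to compound 3 (0.31 log units; beyond the scatter). Both are small, and returning to a single-group aryl from compound 3 has so far meant at most a modest move toward lower numbers. Nothing in the series tells whether a methoxy group behaves like a bromine here; no oxygen-bearing aryl has been measured.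

In this assay compound 4 is therefore expected at about 18000 nM, with a range of 7000 nM to 45000 nM. The expected step is a 1.5-fold lower number from compound 3 to compound 4 (0.18 log units; within the scatter), which may well fall within the scatter.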

Compound 4, half-maximal inhibitory concentration: 25500 nM
The estimate for compound 4 lay 1.4-fold (0.15 log units) below the measured number; the range from low to high includes it.
By their numbers in this assay, from the lowest: compounds 2, 1, 4 and 3 (each within the scatter of the next, the first and the last beyond it).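

Placed on this saturated ring carbon, 4-methoxyphenyl brings the first oxygen-bearing aryl into the series, and in this assay the result stays within the scatter of all three earlier compounds (a 1.1-fold lower number from compound 3 to compound 4 (0.03 log units; within the scatter)) (a 1.1-fold higher number from compound 1 to compound 4 (0.04 log units; within the scatter)) (a 1.9-fold higher number from compound 2 to compound 4 (0.29 log units; within the scatter)). Compound 4 carries a single group on the aryl, as compound 2 does, yet it cannot be separated from compound 2 or from compound 3, so the series does not show single-group aryls as a class standing apart from 2,4-dichlorophenyl. No measurement at hand offers an explanation for this reading.

Still open, going by these compounds, is whether any aryl at this position can move the number clearly away from that of compound 1, since none of the steps from compound 1 lies beyond the scatter. The compounds shown also leave untested how an amine or a carboxylic acid on the phenyl ring, or a longer chain such as ethoxy or butoxy in place of methoxy, would read in this assay.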